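Series notes: aryl-to-fused-heteroaryl swap on the exocyclic alkene

The source may report more compounds than this note shows. Statements on the series, on what has been measured and on what is new or still open speak of the compounds shown alone.

Measured compounds:
- compound 1, `CCOC(=O)C1=C(Nc2ccccc2)S/C(=C\c2ccc(OC)cc2)C1=O`: 32.9%
- compound 2, `CCOC(=O)C1=C(Nc2ccccc2Br)S/C(=C\c2ccc[nH]2)C1=O`: 62.7%
- compound 3, `CCOC(=O)C1=C(Nc2ccccc2)S/C(=C\c2ccc(C(=O)OCC)[nH]2)C1=O`: 60.1%

In a functional assay on JAR cells (Homo sapiens) for inhibition, read by MTT assay, with a stated time of 72 h, tested at 10 uM (a higher number here means more inhibition at the concentration tested (going by the name of the read-out), a lower number less inhibition), compound 1 gives 32.9%, the lowest of the three numbers. Compound 3 gives 60.1% and compound 2 gives 62.7%; both differences to compound 1 are beyond the scatter, while compound 2 and compound 3 lie within the scatter of each other. Compound 2 and compound 3 each carry a five-membered aromatic ring with one hetero atom and one hydrogen-bond donor in the position where compound 1 carries the 4-methoxyphenyl, though compound 2 also differs at the aniline.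

Compound 4, `CCOC(=O)C1=C(Nc2ccccc2)S/C(=C\c2cc3ccncc3[nH]2)C1=O`, is not yet measured. It differs from compound 1 in one place: a group of 9 heavy atoms (7 carbon, 2 nitrogen; one five-membered aromatic ring with 1 hetero atom, one six-membered aromatic ring with 1 hetero atom) in place of a group of 8 heavy atoms (7 carbon, 1 oxygen; one six-membered aromatic ring of carbon only), on a double-bonded chain carbon bound to a double-bonded ring carbon

The entering group shares with compound 2 and compound 3 the five-membered aromatic ring with one hetero atom and the single hydrogen-bond donor. On that basis the step in this assay is expected to go upward and beyond the scatter, estimated as a number 22.1 percentage points higher from compound 1 to compound 4 (beyond the scatter). Compound 4 is expected to give about 55%, with a range from 35% to 75%. This expectation rests on compound 3 with 60.1% and on compound 2 with 62.7%. For the measured compounds named here, no measured step isolates the fused ring itself, so the range is kept wide.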

Compound 4, a percentage reported as inhibition, at one concentration (the size of the read-out at that concentration, not a potency): 26.3%
Estimate against measurement, compound 4: 28.7 percentage points above, outside the stated range (below it).
By their numbers in this assay, from the lowest: compounds 4 and 1 (each within the scatter of the next); then compounds 3 and 2 (each within the scatter of the next).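

In this assay the exchange of the 4-methoxyphenyl for the fused group, on the double-bonded chain carbon bound to a double-bonded ring carbon, gives a number 6.6 percentage points lower from compound 1 to compound 4 (within the scatter), so this position accepts the larger two-ring group without a step beyond the scatter. A five-membered aromatic ring with one hetero atom and a hydrogen-bond donor at this place is therefore not enough on its own to reach the number of compound 3 at 60.1%: compound 4 carries both and gives 26.3%, and among the compounds with the plain aniline, only compound 3 stands apart. Nothing on hand bears on the reason for this result.

The compounds shown do not separate the contribution of the six-membered aromatic ring with its hetero atom in compound 4 from that of the ring fusion, nor show whether the ethyl ester on the five-membered ring of compound 3 is what goes with its number. A carboxylic acid in place of that ethyl ester, or an amine on the fused group, would remain to be placed in this series.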